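The source may report more compounds than this note shows. Statements on the series, on what has been measured and on what is new or still open speak of the compounds shown alone.

Measured so far in a functional assay on Bel-7402 cells (Homo sapiens) for inhibition, read by MTT assay, with a stated time of 24 h, tested at 1 ug/mL; a higher number here means more inhibition of growth at the concentration tested, a lower number less inhibition of growth:
- compound 1 `O=C(CCCCC(S)CCS)NO`: 9.12%
- compound 2 `O=C(CCCCC(S)CCS)Nc1ccccc1`: 1.32%
- compound 3 `O=C(CCCCC(S)CCS)Nc1cccc(C(F)(F)F)c1`: 1.66%

Not yet measured: compound 4 `O=C(CCCCC(S)CCS)Nc1ccc(OC(F)(F)F)cc1`.

Compound 2, at 1.32%, sits within the scatter of both compounds it connects to by a single change, so it cannot be ranked against either one. The change to compound 4 is trifluoromethoxy in place of hydrogen on an aromatic carbon, para to a large group.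

Going by the values given here, the closest precedent is compound 3, also a substitution on an aromatic carbon, with trifluoromethyl in place of hydrogen. That step is a number 0.3 percentage points higher from compound 2 to compound 3 (within the scatter). The other measured step, a number 7.8 percentage points lower from compound 1 to compound 2 (within the scatter), is a change on an amide-type nitrogen and bears on this question only indirectly, though it also stays within the scatter. Among the compounds with values here, no compound with trifluoromethoxy has been measured, so the precedent is only partial.

Both measured steps are small, and no step beyond the scatter is expected in this assay, in either direction. The expected step is a number 1.7 percentage points higher from compound 2 to compound 4 (within the scatter). For compound 4 the estimated value is 3%, with an expected range from 0% to 11%.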

Compound 4, percent growth inhibition at one concentration: 7.32%
Estimate against measurement, compound 4: 4.3 percentage points below, within the range that was stated.
By their numbers in this assay, from the lowest: compounds 2, 3, 4 and 1 (each within the scatter of the next).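

Working notes on the series: in this assay, placing trifluoromethoxy on the aromatic carbon para to a large group gives a number 6 percentage points higher from compound 2 to compound 4 (within the scatter), so this position accepts a group of 5 heavy atoms, including oxygen and fluorine, without a step beyond the scatter. The earlier aromatic step covered only trifluoromethyl; compound 4 extends the same reading to a second fluorinated group at a named position, and neither substitution can be separated from the unsubstituted phenyl amide, compound 2. Nothing measured on these groups accompanies the result, so the data offer no explanation for the size of this step.

Going by these compounds, it remains open whether a group of another kind at this aromatic carbon, such as an amine or a carboxylic acid, would move the number beyond the scatter, or whether a longer chain in the shared core would do so. The readings also come from a single tested concentration and time, so any separation among compounds 2, 3 and 4 at higher concentrations remains an open question.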